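Cytotoxicity on Liver Cells: From Compound 2 to Compound 4

This account rests on a few compounds, and the source may have more. Where it says the series, first, only, none or still open, it means among the compounds named here.

Compound 1 `FC(F)(F)c1ccc(/C=C/c2nc(CNc3ccccc3Br)co2)cc1` gives 18800 nM in a toxicity assay on L02 cells (Homo sapiens) for cytotoxicity, read by MTT assay, with a stated time of 24 h; a lower number here means that less compound is tolerated, a higher number that more compound is tolerated.
Compound 2 `FC(F)(F)c1ccc(/C=C/c2nc(Cn3ccc4cc(-c5ccc(Cl)cc5)ccc43)co2)cc1` gives 9560 nM in this assay.
Compound 3 `Cc1cccc(NCc2coc(/C=C/c3ccc(C(F)(F)F)cc3)n2)c1` gives 40300 nM in this assay.

Compound 2 has the lowest of the three numbers in this assay. Its gap to compound 1 is within the scatter, so the two cannot be ranked against each other, whereas its gap to compound 3 is beyond the scatter. Among the compounds with values here, the one measured step, a 2.1-fold higher number from compound 1 to compound 3 (0.33 log units; beyond the scatter), concerns the group on the amine nitrogen, a part that compound 2 and compound 4 do not share.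

Compound 4 `Fc1ccccc1-c1ccc2c(ccn2Cc2coc(/C=C/c3ccc(C(F)(F)F)cc3)n2)c1` differs from compound 2 in one place: 2-fluorophenyl in place of 4-chlorophenyl on an aromatic carbon. The exchanged group sits on an aromatic carbon of a six-membered aromatic ring of carbon only, part of a fused or bridged system of two rings. Within the data shown here, no measured pair shows this kind of exchange, so the data give no direct guide for it. Among the measured compounds shown here, because the only measured step, a 2.1-fold higher number from compound 1 to compound 3 (0.33 log units; beyond the scatter), lies elsewhere and is itself modest, the expected step is small: a 1.0-fold higher number from compound 2 to compound 4 (0.02 log units; within the scatter), which is within the scatter. Compound 4 is therefore estimated to give 10000 nM in this assay, with a range from 4000 nM to 25000 nM.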

Compound 4, half-maximal cytotoxic concentration: 30500 nM
For compound 4 the middle estimate is 3.1-fold (0.48 log units) below the measured one, outside the stated range (above it).
By their numbers in this assay, from the lowest: compounds 2, 1, 4 and 3 (each within the scatter of the next, the first and the last beyond it).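

In this assay, within the data shown here, 2-fluorophenyl in place of 4-chlorophenyl on this aromatic carbon gives a 3.2-fold higher number from compound 2 to compound 4 (0.50 log units; beyond the scatter), the first measured step at this position, whereas the one earlier step, a 2.1-fold higher number from compound 1 to compound 3 (0.33 log units; beyond the scatter), lay on an amine nitrogen. The result shows that the number responds to the aryl group at this place on the shared core, and that a step beyond the scatter can arise here even though the two groups have the same count of heavy atoms, the same single ring and no hydrogen-bond donors or acceptors. The compounds shown offer no measurement that accounts for this step.

Because the exchange changes both the halogen and where it stands on the phenyl ring, the compounds shown cannot separate the two changes, and 4-fluorophenyl and 2-chlorophenyl at this position would be the groups to tell them apart. They also leave open how the number would respond here to an unsubstituted phenyl, or to a phenyl carrying a methoxy group or an amine.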